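A few compounds are considered here, and "the series" means these few. Any claim that something is new, unique, unknown or untested is made for them only; others in the source may bear on it.

Measured so far in an ADME assay on J774.1 cells (Mus musculus) for cytotoxicity, with a stated time of 48 h; a lower number here means that less compound is needed, a higher number that more compound is needed for the effect:
Compound 1, `C=CCN1[C@H](c2ccccc2)C(C(=O)OC)C(=O)C(C(=O)OC)[C@@H]1c1ccccc1`, sits at the assay limit of > 100 uM in this assay, so no number is known for it.
Compound 2, `C=CCN1[C@H](c2ccc([N+](=O)[O-])cc2)C(C(=O)OC)C(=O)C(C(=O)OC)[C@@H]1c1ccc([N+](=O)[O-])cc1`, gives 50.3 uM in this assay.
Compound 3, `COC(=O)C1C(=O)C(C(=O)OC)[C@H](c2ccccn2)N(Cc2ccccc2)[C@@H]1c1ccccn1`, gives 34 uM in this assay.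

Compound 3 holds the lowest of the two numbers in this assay. Its nearest neighbour is compound 2, and the gap between the two lies within the usual scatter of repeated measurements, so no order between compound 3 and compound 2 can be read from the numbers. Compound 1 stands apart at the limit of > 100 uM in this assay, at which 1 of the 3 values shown sits. Among the compounds with values here, no pair of measured compounds differs in one place, so no single measured step is available.

Compound 4, `COC(=O)C1C(=O)C(C(=O)OC)[C@H](c2ccccn2)N(CCCO)[C@@H]1c1ccccn1`, has not yet been measured in this assay. Against compound 3 the counted difference is 2-hydroxyethyl in place of phenyl on a saturated chain carbon bound to an amine nitrogen in a ring. The same difference, cut one bond further out, reads benzyl to 3-hydroxypropyl. Within the data shown here, no measured pair in the set carries a change of this kind, so nothing in the data fixes its size or direction. The expectation for compound 4 is a small step of a 1.8-fold higher number from compound 3 to compound 4 (0.25 log units; within the scatter), upward, close to the edge of the scatter. Compound 4 is estimated at 60 uM, in the range 25 uM to 150 uM.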

Compound 4, concentration for half-maximal effect: 32 uM
Compound 4: the middle estimate sits 1.9-fold (0.27 log units) above what was measured; the range from low to high includes it.
By their numbers in this assay, from the lowest: compounds 4, 3 and 2 (each within the scatter of the next). At a limit, above all of these: compound 1.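

Within the data shown here, this is the first single-place step: in this assay, the change from benzyl to 3-hydroxypropyl on the amine nitrogen gives a 1.1-fold lower number from compound 3 to compound 4 (0.03 log units; within the scatter), so the two compounds cannot be told apart. At this position, on the saturated chain carbon bound to an amine nitrogen in a ring, 2-hydroxyethyl can take the place of phenyl without a readable shift in the number, even though the six-membered aromatic ring of carbon only leaves and a hydrogen-bond donor and acceptor enter. The compounds shown offer no measured property that bears on this step.

This single step, taken on one core, leaves open whether a chain ending in an amine or a carboxylic acid, or a longer chain ending in hydroxyl, would move the number beyond the scatter. It also leaves open whether the same exchange would read the same way with the other ring substituents of the series, since the compounds carrying an allyl group on the nitrogen have no single-place partner here.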